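Bromo on the phenyl ring of two hydroxamate cores

The source may hold more compounds than are shown below. What is called first, only, known or untested is meant among the compounds shown, and "the series" means these compounds.

Measured compounds:
compound 1, `O=C(NO)c1coc(-c2ccccc2)n1`: 270 nM
compound 2, `O=C(NO)c1coc(-c2ccccc2Br)n1`: 2180 nM
compound 3, `O=C(NO)c1noc(-c2ccccc2)n1`: 112 nM

All three numbers come from an assay on isolated protein for inhibition of protein deacetylase HDAC6 (Homo sapiens), read by fluorescence, with a stated time of 90 min; a lower number here means a stronger inhibitor, a higher number a weaker inhibitor. Compound 3 stands lowest of the three; compound 1 is nearest to it, compound 2 furthest. Within the core of compound 1 the change bromo in place of hydrogen on an aromatic carbon made the step of an 8.1-fold higher number from compound 1 to compound 2 (0.91 log units; beyond the scatter). How the core of compound 3 differs from that of compound 1 is not broken down here.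

Compound 4, `O=C(NO)c1noc(-c2ccc(Br)cc2)n1`, is still to be measured in this assay. It arises from compound 3 by bromo in place of hydrogen on an aromatic carbon. Among the compounds with values here, this is the same kind of change as the one from compound 1 to compound 2, not the same: in compound 2 the bromo sits ortho to a group of 9 heavy atoms, in compound 4 para to it. Within the data shown here, only one measured step of this kind exists, and it was made on the other core. Among the measured compounds shown here, for compound 4 the expected step is a 2.7-fold higher number from compound 3 to compound 4 (0.43 log units; beyond the scatter), somewhat smaller than the earlier one because the place differs and an 8.1-fold higher number from compound 1 to compound 2 (0.91 log units; beyond the scatter) is the sole precedent. Compound 4 is estimated at 300 nM.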

Compound 4, half-maximal inhibitory concentration: 2770 nM
Compound 4: the middle estimate sits 9.2-fold (0.97 log units) below what was measured; measured number outside the range, above it.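

In this assay the bromo change moved the number the same way on both cores, and on the core of compound 3 it gave a 25-fold higher number from compound 3 to compound 4 (1.39 log units; beyond the scatter), so the loss of inhibition carried over in direction across this single pair of cores. The size of the step did not carry over: the same change on two cores in this assay, an 8.1-fold higher number (0.91 log units; beyond the scatter) from compound 1 to compound 2 and a 25-fold higher number (1.39 log units; beyond the scatter) from compound 3 to compound 4, 3.1-fold (0.49 log units) apart, beyond the scatter of two such steps

This does not show that the core sets the size of the step, since the bromo of compound 4 sits para to a group of 9 heavy atoms while that of compound 2 sits elsewhere on the phenyl ring, and core and place therefore change together between the two steps.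

The compounds shown leave open how a bromo at one and the same place would behave on each of the two cores. They also leave open whether the rise belongs to bromo alone or would also appear with a chloro, a methoxy or an amine on the phenyl ring.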